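Swapping a Small Amide Substituent for Dipentylamino

The compounds below may be only part of what the source reports. "The series", "measured", "known", "first", "only" and "open" are said of these compounds alone.

Compound 1, `CCNC(=O)/C=C/c1c(/C=C/c2ccc(OC)cc2)cc(OC)cc1OC`, in a functional assay on A549 cells (Homo sapiens) for inhibition, read by MTT assay, with a stated time of 48 h; on this read-out lower numbers stand for stronger inhibition and higher numbers for weaker inhibition: 7860 nM
Compound 2, `CCCCCCCCNC(=O)/C=C/c1c(/C=C/c2ccc(OC)cc2)cc(OC)cc1OC`, in this assay: 8660 nM
Compound 3, `COc1ccc(/C=C/c2cc(OC)cc(OC)c2/C=C/C(=O)N2CCC(Cl)CC2)cc1`, in this assay: 2080 nM

Compound 1 stands second highest of the three numbers in this assay. Its nearest neighbour is compound 2, and the step of a 1.1-fold higher number from compound 1 to compound 2 (0.04 log units; within the scatter) lies within the scatter, so the longer chain in compound 2 changes nothing that can be read. The furthest is compound 3, reached by a 3.8-fold lower number from compound 1 to compound 3 (0.58 log units; beyond the scatter), a modest gain; a 4.2-fold lower number from compound 2 to compound 3 (0.62 log units; beyond the scatter) tells the same story from compound 2.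

Compound 4, `CCCCCN(CCCCC)C(=O)/C=C/c1c(/C=C/c2ccc(OC)cc2)cc(OC)cc1OC`, is not yet measured. It differs from compound 1 by dipentylamino in place of ethylamino on a carbonyl carbon. Going by the values given here, two measured steps bear on it: the chain-length step shows no effect, while the step to compound 3, which like compound 4 carries a group with no hydrogen-bond donor, shows a modest drop. A modest drop is therefore expected for compound 4 as well, a 2.0-fold lower number from compound 1 to compound 4 (0.29 log units; within the scatter). Compound 4 is estimated at 4000 nM, with a range from 1500 nM to 12000 nM.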

Compound 4, half-maximal inhibitory concentration: 7490 nM
Compound 4: the middle estimate sits 1.9-fold (0.27 log units) below what was measured, and the stated range covers the measured number.
By their numbers in this assay, from the lowest: compound 3; then compounds 4, 1 and 2 (each within the scatter of the next).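

On this carbonyl carbon, dipentylamino reads the same as the ethylamino and octylamino groups in this assay: both a 1.0-fold lower number from compound 1 to compound 4 (0.02 log units; within the scatter) and a 1.2-fold lower number from compound 2 to compound 4 (0.06 log units; within the scatter) show no readable change, even though the amide hydrogen is gone. Losing that hydrogen therefore does not by itself bring the lower number seen for compound 3, which also lacks it, and a 3.6-fold higher number from compound 3 to compound 4 (0.56 log units; beyond the scatter) sets the 4-chloropiperidin-1-yl group apart from the open dipentylamino chains. Nothing measured here explains why these groups differ.

The compounds shown do not separate the contribution of the ring in compound 3 from that of its chlorine. Plain piperidin-1-yl, with no chlorine, and an open chain ending in chlorine would pull those two features apart.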